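Diethylamino extension on the chain of compound 1

The compounds below may be only part of what the source reports. "The series", "measured", "known", "first", "only" and "open" are said of these compounds alone.

Measured so far in a functional assay on MCF7 cells (Homo sapiens) for antiproliferative activity, read by MTT assay, with a stated time of 72 h; a higher number here means a weaker inhibitor, a lower number a stronger inhibitor:
compound 1 `CCNc1cc(C)c2cc(NC(=O)c3ccc(Cl)c(Cl)c3)ccc2n1`: 48600 nM
compound 2 `CCN1CCN(c2cc(C)c3cc(NC(=O)c4ccccc4C)ccc3n2)CC1`: 10900 nM
compound 3 `CCN1CCN(c2cc(C)c3cc(NC(=O)c4ccccc4Cl)ccc3n2)CC1`: limit, > 50000 nM

Among the compounds with values here, compound 1 gives the highest number of the two numbers known, with compound 2 as nearest neighbour at a lower value; compound 2 differs from compound 1 both in the substituent on the core and in the amide aryl part, so no single step between them is defined. The value of compound 3 in this assay is a limit, not a number (the limit of > 50000 nM in this assay, at which 1 of the 3 values shown sits). Within the data shown here, the one measured step, an at least 4.5-fold higher number from compound 2 to compound 3 (0.66 log units; beyond the scatter), concerns the amide aryl group and does not touch the chain that is varied here.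

Compound 4 `CCN(CC)CCNc1cc(C)c2cc(NC(=O)c3ccc(Cl)c(Cl)c3)ccc2n1` is compound 1 with diethylamino in place of hydrogen on a saturated chain carbon, two bonds along the chain from a nitrogen on an aromatic ring. Among the measured compounds shown here, no measured step bears on this change, so the expectation rests only on compound 2 carrying an amine-bearing substituent on the core and giving 10900 nM. A modest lowering is expected, a 2.4-fold lower number from compound 1 to compound 4 (0.39 log units; beyond the scatter), with wide uncertainty. Compound 4 is estimated at 20000 nM, range 6000 nM to 50000 nM.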

Compound 4, half-maximal inhibitory concentration: 1420 nM
Estimate against measurement, compound 4: 14-fold (1.15 log units) above; measured number outside the range, below it.
By their numbers in this assay, from the lowest: compound 4; then compound 2; then compound 1. At a limit, above all of these: compound 3.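

Working notes on the chain. In this assay, within the data shown here, the change from ethylamino to (2-(diethylamino)ethyl)amino gives a 34-fold lower number from compound 1 to compound 4 (1.53 log units; beyond the scatter) and is the first measured step on this chain. The saturated chain carbon two bonds along the chain from a nitrogen on an aromatic ring therefore tolerates diethylamino in place of hydrogen, and the number responds strongly to this change with the 3,4-substitution of the amide aryl group held fixed. Nothing shown bears on the reason for this step.

As far as these compounds go, whether the step needs diethylamino in particular remains open: dimethylamino, a pyrrolidine ring or a longer propyl link to the amine would test this. Also open, from the compounds shown here alone, is whether the same chain extension would lower the number with the amide aryl groups of compound 2 and compound 3.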